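Aryl sulfonate amides and ureas: extending the urea chain

The compounds below may be only part of what the source reports. "The series", "measured", "known", "first", "only" and "open" are said of these compounds alone.

Measured so far in a functional assay on MCF7 cells (Homo sapiens) for antiproliferative activity, read by sulforhodamine B assay, with a stated time of 48 h; a lower number here means a stronger inhibitor, a higher number a weaker inhibitor:
compound 1 `CC(=O)Nc1ccc(S(=O)(=O)Oc2ccccc2C(C)C)cc1` gives 16000 nM
compound 2 `CCC(=O)Nc1ccc(S(=O)(=O)Oc2ccccc2C(C)C)cc1` gives 11000 nM
compound 3 `CCNC(=O)Nc1ccc(S(=O)(=O)Oc2ccccc2C(C)C)cc1` gives 10000 nM

Compound 3 holds the lowest of the three numbers in this assay, but its neighbours sit close: a 1.1-fold lower number from compound 2 to compound 3 (0.04 log units; within the scatter) and a 1.6-fold lower number from compound 1 to compound 3 (0.20 log units; within the scatter) are both within the scatter, so no ordering among compounds 1, 2 and 3 can be claimed. The three share one core and differ only in the group on the carbonyl carbon.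

Compound 4 `CCCCCNC(=O)Nc1ccc(S(=O)(=O)Oc2ccccc2C(C)C)cc1` is the next member; relative to compound 3 the change is propyl in place of hydrogen on a saturated chain carbon, two bonds along the chain from an amide-type nitrogen, so the ethylamino becomes pentylamino. Among the compounds with values here, the only measured step that lengthens a chain is a 1.5-fold lower number from compound 1 to compound 2 (0.16 log units; within the scatter), a single added carbon and within the scatter. Within the data shown here, no measured step adds three carbons, and none goes beyond the scatter at all, so there is no basis for expecting a step of real size in this assay in either direction. The expected step is a 1.3-fold lower number from compound 3 to compound 4 (0.10 log units; within the scatter), leaning slightly toward a lower number because a 1.5-fold lower number from compound 1 to compound 2 (0.16 log units; within the scatter) and a 1.6-fold lower number from compound 1 to compound 3 (0.20 log units; within the scatter) both point that way, though neither is outside the scatter. Compound 4 is therefore estimated at 8000 nM, with a range of 3000 nM to 20000 nM.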

Compound 4, half-maximal inhibitory concentration: 4000 nM
For compound 4 the middle estimate is 2.0-fold (0.30 log units) above the measured one; the range from low to high includes it.
By their numbers in this assay, from the lowest: compound 4; then compounds 3, 2 and 1 (each within the scatter of the next).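

In this assay, within the data shown here, the change from ethylamino to pentylamino gives the first step that lies beyond the scatter, a 2.5-fold lower number from compound 3 to compound 4 (0.40 log units; beyond the scatter), so added propyl on a saturated chain carbon, two bonds along the chain from an amide-type nitrogen, registers in a way the changes among compounds 1, 2 and 3 did not. Among these compounds, the separation holds against the two amides as well, with a 2.8-fold lower number from compound 2 to compound 4 (0.44 log units; beyond the scatter) and a 4.0-fold lower number from compound 1 to compound 4 (0.60 log units; beyond the scatter), which makes compound 4 the only member whose steps to all the others are beyond the scatter, although each of these steps is modest. Nothing measured on these compounds bears on why the pentylamino chain goes with the lower number.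

From the compounds shown here alone, with only ethylamino and pentylamino to compare, the shape of the chain-length trend remains open: butylamino could lie anywhere around these values, and a longer chain such as heptylamino or octylamino could extend the trend or reverse it. Also open, going by these compounds, is whether the step depends on a plain alkyl chain, or would survive a terminal amine, a terminal carboxylic acid or a cyclohexyl group at the end of the chain.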